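The source may report more compounds than this note shows. Statements on the series, on what has been measured and on what is new or still open speak of the compounds shown alone.

Values in a functional assay on PC-3 cells (Homo sapiens) for cytotoxicity, with a stated time of 48 h (on this read-out lower numbers stand for stronger inhibition and higher numbers for weaker inhibition), so far:

- compound 1 `COc1cc(OC)c(C(=O)/C=C/c2ccccc2SC)c(OC)c1` gives 7600 nM
- compound 2 `COc1cccc(/C=C/C(=O)c2c(OC)cc(OC)cc2OC)c1` gives 3100 nM
- compound 3 `COc1cc(OC)c(C(=O)/C=C/c2ccc(F)cc2)c(OC)c1` gives 5500 nM

Not yet measured: compound 4 `COc1cc(OC)c(C(=O)/C=C/c2ccc(Br)cc2)c(OC)c1`

Compound 3 sits within the scatter of both other measured compounds. The two steps that reach it are a 1.4-fold lower number from compound 1 to compound 3 (0.14 log units; within the scatter) and a 1.8-fold higher number from compound 2 to compound 3 (0.25 log units; within the scatter). Within the data shown here, only one step among the three compounds clears the scatter, and it is a modest one: a 2.5-fold lower number from compound 1 to compound 2 (0.39 log units; beyond the scatter).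

The change now in view is bromo in place of fluoro on an aromatic carbon, para to a large group, and it is counted as bromo in place of fluoro on an aromatic carbon. Among the measured compounds shown here, no measured step swaps one halogen for another, so the evidence is indirect. All three measured steps exchange the whole substituted phenyl group on the double-bonded chain carbon, and the largest of them is still only a 2.5-fold lower number from compound 1 to compound 2 (0.39 log units; beyond the scatter). A single-atom exchange on compound 3 , which gives 5500 nM, therefore gives no ground for expecting a large move in this assay, and no direction can be called from these data.

The expected outcome is a 1.1-fold lower number from compound 3 to compound 4 (0.06 log units; within the scatter), with no shift beyond the scatter anticipated.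

For compound 4 the estimated value is 4800 nM, with an expected range from 2300 nM to 10000 nM.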

Compound 4, half-maximal inhibitory concentration: 7100 nM
Estimate against measurement, compound 4: 1.5-fold (0.17 log units) below; low and high end bracket the measured number.
By their numbers in this assay, from the lowest: compounds 2, 3, 4 and 1 (each within the scatter of the next, the first and the last beyond it).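

In this assay, the exchange of fluoro for bromo on an aromatic carbon, para to a large group, gives a 1.3-fold higher number from compound 3 to compound 4 (0.11 log units; within the scatter), so this first direct halogen swap does not separate the two halogens at this position. The 4-bromophenyl group also gives a 1.1-fold lower number from compound 1 to compound 4 (0.03 log units; within the scatter), which does not separate it from 2-(methylsulfanyl)phenyl, while a 2.3-fold higher number from compound 2 to compound 4 (0.36 log units; beyond the scatter) is a modest step beyond the scatter, so compound 2, with its 3-methoxyphenyl group, now stands apart from both compound 1 and compound 4, though still not from compound 3. No measurement is available that bears on the reason for any of these steps.

Whether this position stays as flat with chloro or iodo remains open, since fluoro and bromo are the only halogens in the compounds shown. Also open, on these data alone, is whether an amine or a carboxylic acid on the same aromatic carbon would move the number beyond the scatter of compound 3, and in which direction.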